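Sulfonamide aryl variation on a shared quinone core

The compounds below may be only part of what the source reports. "The series", "measured", "known", "first", "only" and "open" are said of these compounds alone.

Measured compounds:
compound 1 `Cc1ccccc1S(=O)(=O)NC(C1=CC(=O)c2c(O)ccc(O)c2C1=O)C(C)C`: 190 nM
compound 2 `COc1ccc(S(=O)(=O)NC(C2=CC(=O)c3c(O)ccc(O)c3C2=O)C(C)C)c(OC)c1`: 400 nM
compound 3 `CC(C)C(NS(=O)(=O)c1ccc(Cl)cc1)C1=CC(=O)c2c(O)ccc(O)c2C1=O`: "not determined" (no result reported)

Going by the values given here, in a functional assay on HL-60 cells (Homo sapiens) for cytotoxicity, read by MTT assay (a higher number here means a weaker inhibitor, a lower number a stronger inhibitor), compound 1 gives 190 nM and compound 2 gives 400 nM; the step of a 2.1-fold higher number from compound 1 to compound 2 (0.32 log units; beyond the scatter) is the only measured aryl swap on the sulfonyl sulfur. Compound 3 `CC(C)C(NS(=O)(=O)c1ccc(Cl)cc1)C1=CC(=O)c2c(O)ccc(O)c2C1=O` has "not determined" (no result reported) in this assay, so it cannot be placed against the others.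

Compound 4 `CC(C)C(NS(=O)(=O)c1cccc(Br)c1)C1=CC(=O)c2c(O)ccc(O)c2C1=O` differs from compound 3 by 3-bromophenyl in place of 4-chlorophenyl on a sulfonyl sulfur. Among the compounds with values here, the one aryl-swap step known in this assay was modest, so for compound 4 a step of similar or smaller size is expected, direction unknown, with a number near compound 1 and compound 2. Compound 4 is expected at about 300 nM, within 120 nM to 800 nM.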

Compound 4, half-maximal inhibitory concentration: 790 nM
The estimate for compound 4 lay 2.6-fold (0.42 log units) below the measured number; the measured number falls inside the stated range.
By their numbers in this assay, from the lowest: compound 1; then compounds 2 and 4 (each within the scatter of the next).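

In this assay, 3-bromophenyl on the sulfonyl sulfur in place of 2-methylphenyl gives a 4.2-fold higher number from compound 1 to compound 4 (0.62 log units; beyond the scatter), which widens the range seen at this position, whereas in place of 2,4-dimethoxyphenyl it gives a 2.0-fold higher number from compound 2 to compound 4 (0.30 log units; within the scatter) and does not separate those two groups. Compound 3 has no result, so the swap from 4-chlorophenyl cannot be read. No measurement here accounts for these differences. Still open, going by these compounds, is how a sulfonyl aryl carrying an amine or a carboxylic acid would compare with 2-methylphenyl. Also open, on these data alone, is how a simple alkyl chain on the sulfonyl sulfur would compare.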